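Working notes on the amide-tail series, toward compound 4

The source may report more compounds than this note shows. Statements on the series, on what has been measured and on what is new or still open speak of the compounds shown alone.

Three members of the series have so far been run in an assay on isolated protein for inhibition of thyroid hormone receptor alpha (Homo sapiens), read by fluorescence polarization; a lower number here means a stronger inhibitor, a higher number a weaker inhibitor. Compound 1 `CS(=O)(=O)c1ccc(C(=O)NCCC(=O)N2CCc3ccccc32)cc1[N+](=O)[O-]` gives > 60000 nM there, which is a limit of the assay and not a number. Compound 2 `CC1CCN(C(=O)CCNC(=O)c2ccc(S(C)(=O)=O)c([N+](=O)[O-])c2)CC1` gives > 60000 nM, again only a limit. Compound 3 `CS(=O)(=O)c1ccc(C(=O)NCCC(=O)N2CCc3ccccc3C2)cc1[N+](=O)[O-]` gives > 60000 nM, also a limit. Compound 2 thus stands at the limit of > 60000 nM in this assay, at which 3 of the 3 values shown sit, placed no differently from the other two. The three steps among these compounds, a step that the two limits leave unreadable from compound 1 to compound 2, a step that the two limits leave unreadable from compound 1 to compound 3 and a step that the two limits leave unreadable from compound 2 to compound 3, are all left unreadable, both ends of each sitting at the limit.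

Compound 4 `CS(=O)(=O)c1ccc(C(=O)NCCCC(=O)N2CCCCC2)cc1[N+](=O)[O-]` has not yet been run in this assay. It differs from compound 2 by ((piperidin-1-yl)carbonyl)methyl in place of (4-methylpiperidin-1-yl)carbonyl on a saturated chain carbon, two bonds along the chain from an amide-type nitrogen. Among the measured compounds shown here, no measured step carries a readable size that bears on this change; the three pairs show only that each exchange of the amide tail has left the compound at the limit. The expectation for compound 4 is therefore a step of no readable size, a number no higher from compound 2 to compound 4 (the limit leaves the size open), with the compound likely to remain at the limit. Compound 4 is estimated at 60000 nM, within a range of 20000 nM to 200000 nM.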

Compound 4, half-maximal inhibitory concentration: > 60000 nM
Compound 4 was reported as a limit; the forecaster's own chance of this, stated with the estimate: 85%; the middle value lies on the limit itself.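

Compound 2 and compound 4 both stand as limits and not as numbers in this assay, so the step between them cannot be read: the limit of > 60000 nM in this assay, at which 4 of the 4 values shown sit.

The compounds shown leave open whether any change to the amide tail gives a measurable value in this assay, and so how these compounds rank against one another.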